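This account rests on a few compounds, and the source may have more. Where it says the series, first, only, none or still open, it means among the compounds named here.

Measured compounds:
- compound 1 `Oc1cccc(-c2cc(-c3ccc(Cl)cc3)nc(-c3cccs3)c2)c1` gives 11600 nM
- compound 2 `Oc1ccc(-c2cc(-c3ccc(Cl)cc3)nc(-c3cccs3)c2)cc1` gives 7660 nM
- compound 3 `Oc1ccc(-c2cc(-c3ccc(Cl)cc3)nc(-c3ccsc3)c2)cc1` gives 6940 nM

All three were read in a functional assay on DU-145 cells (Homo sapiens) for cytotoxicity, read by CCK-8 assay and cell counting, with a stated time of 2 days; a higher number here means a weaker inhibitor, a lower number a stronger inhibitor. The three values sit close together, and none of the steps among them goes beyond the scatter, so no order among compound 1, compound 2 and compound 3 can be claimed.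

Compound 2 and compound 3 share one change: thiophen-3-yl in place of thiophen-2-yl on an aromatic carbon. The step it made was a 1.1-fold lower number from compound 2 to compound 3 (0.04 log units; within the scatter).

Compound 2 and compound 1 differ by 3-hydroxyphenyl in place of 4-hydroxyphenyl on an aromatic carbon. The step it made was a 1.5-fold higher number from compound 2 to compound 1 (0.18 log units; within the scatter).

Compound 4 `Oc1cccc(-c2cc(-c3ccc(Cl)cc3)nc(-c3ccsc3)c2)c1` has not been measured. It differs from compound 3 by 3-hydroxyphenyl in place of 4-hydroxyphenyl on an aromatic carbon. This is the same kind of change as that from compound 2 to compound 1, but the surroundings are not identical: in compound 2 the place is meta to a thiophen-2-yl group, in compound 3 it is meta to a thiophen-3-yl group. The two cores differ by thiophen-3-yl in place of thiophen-2-yl on an aromatic carbon, a change that by itself gave a step within the scatter.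

For the measured compounds named here, the expectation for compound 4 rests on the one earlier example of this change, a 1.5-fold higher number from compound 2 to compound 1 (0.18 log units; within the scatter), and on compound 3 at 6940 nM. The estimated step from compound 3 to compound 4 in this assay is a 1.4-fold higher number from compound 3 to compound 4 (0.16 log units; within the scatter), set beside the earlier one. Compound 4 is expected to give about 10000 nM, estimated to lie between 5000 nM and 22000 nM.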

Compound 4, half-maximal inhibitory concentration: 11600 nM
Compound 4: middle estimate off by 1.2-fold (0.06 log units), on the low side; the measured number falls inside the stated range.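

In this assay, 3-hydroxyphenyl in place of 4-hydroxyphenyl on the core carrying thiophen-3-yl gave a 1.7-fold higher number from compound 3 to compound 4 (0.22 log units; within the scatter), and this step reads the same as the one on the core carrying thiophen-2-yl: the same change on two cores in this assay, a 1.5-fold higher number (0.18 log units; within the scatter) from compound 2 to compound 1 and a 1.7-fold higher number (0.22 log units; within the scatter) from compound 3 to compound 4, 1.1-fold (0.04 log units) apart, within the scatter of two such steps

The other change, thiophen-3-yl in place of thiophen-2-yl, now also stands on two cores, with no change at the digits printed from compound 1 to compound 4 (within the scatter) on the 3-hydroxyphenyl core, and it too reads the same on both: the same change on two cores in this assay, a 1.1-fold lower number (0.04 log units; within the scatter) from compound 2 to compound 3 and no change at the digits printed (within the scatter) from compound 1 to compound 4, 1.1-fold (0.04 log units) apart, within the scatter of two such steps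

For the compounds shown here, this shows only that neither change moved the number beyond the scatter on either core, so the four compounds form a flat square in which no order can be claimed; it does not show that a real effect of either change carries from core to core, as there is no step here large enough to be told from the scatter.

The compounds shown leave open whether an amine or a carboxylic acid in place of the hydroxy group would give a step beyond the scatter. Also open, from the compounds shown here alone, is whether a step of that size would follow from a methoxy group or a longer alkyl chain in place of the chlorine of the 4-chlorophenyl group, and whether such a step would then carry between the two thiophene cores.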